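The compounds below may be only part of what the source reports. "The series", "measured", "known", "first", "only" and "open" are said of these compounds alone.

Compound 1 `Cc1ccc(CC(C)(Oc2ccc(C(C)C)cc2)C(=O)O)cc1`: < 1 mg/kg (a limit)
Compound 2 `CC(C)c1ccc(OC(C)(Cc2ccc3c(c2)CCCC3)C(=O)O)cc1`: < 5 mg/kg (a limit)
Compound 3 `COc1ccc(Cc2ccc(OC(C)(Cc3ccc(Cl)cc3)C(=O)O)cc2)cc1`: < 10 mg/kg (a limit)

All three entries come from a functional assay on the whole organism for inhibition, with Rattus norvegicus as the target (on this read-out higher numbers stand for an effect only at larger amounts of compound and lower numbers for an effect already at smaller amounts), and none of them is an exact number, so they cannot be ranked against one another. Compound 3 stands at < 10 mg/kg, which is a limit.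

Compound 4 `CC(Cc1ccc(Cl)cc1)(Oc1ccc(Br)cc1)C(=O)O` differs from compound 3 in one place: bromo in place of 4-methoxybenzyl on an aromatic carbon, para to a large group (bromo in place of 4-methoxybenzyl on an aromatic carbon). Within the data shown here, no two measured compounds differ in just one place, so the data give no direct measure of what such a swap does. With nothing to point either way, no step beyond the scatter is expected in this assay. The estimated step that the limit leaves unreadable from compound 3 to compound 4 is therefore only a cautious expectation, anchored on a limit rather than a number. For compound 4 the expected value is 6 mg/kg, with an estimated range of 1 mg/kg to 30 mg/kg.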

Compound 4, dose for half-maximal effect: < 1 mg/kg
Compound 4: no number, only a limit; the forecaster's own chance of this, stated with the estimate: 60%; at least 6.0-fold (0.77 log units) between middle value and limit.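

Compound 3 and compound 4 are both known only as limits in this assay, so the step between them, bromo in place of 4-methoxybenzyl, cannot be read. The compounds shown leave open whether this swap shifts the half-maximal dose at all, and in which direction.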